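A few compounds are considered here, and "the series" means these few. Any claim that something is new, unique, unknown or untested is made for them only; others in the source may bear on it.

Measured so far:
compound 1, `COC(=O)/C=C/c1cccc(N(Cc2ccc(/C=C/c3cc(C(F)(F)F)cc(C(F)(F)F)c3)cc2)C(=O)C2CCCCC2)c1`: 1470 nM
compound 2, `COC(=O)/C=C/c1cccc(N(Cc2ccc(-c3ccc(C)cc3)cc2)C(=O)C(C)C)c1`: 118 nM
compound 3, `COC(=O)/C=C/c1cccc(N(Cc2ccc(-c3ccc(F)c(Cl)c3)cc2)C(=O)C2CCCCC2)c1`: 66 nM

All values come from an assay on isolated protein with Bile acid receptor (Homo sapiens) as the target; on this read-out higher numbers stand for an effect only at larger amounts of compound and lower numbers for an effect already at smaller amounts. Compound 3 gives 66 nM, the lowest of the three numbers. Compound 2 gives 118 nM, which lies within the usual scatter of the value of compound 3, so no order between these two can be read. Compound 1 gives 1470 nM, and its gap to compound 3 lies beyond the scatter; compound 1 and compound 3 differ in more than one place, so that gap cannot be assigned to any single change.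

Compound 4 is `COC(=O)/C=C/c1cccc(N(Cc2ccc(/C=C/c3ccc(OC)cc3)cc2)C(=O)C2CCCCC2)c1` and is not yet measured. It differs from compound 3 in one place: 2-(4-methoxyphenyl)ethenyl in place of 3-chloro-4-fluorophenyl on an aromatic carbon. Compound 1 likewise carries a group with a double bond outside aromatic rings, and its number is the highest of the three, yet compound 1 and compound 3 differ in other ways as well, so this gives only a weak pointer. In this assay the step of a 6.1-fold higher number from compound 3 to compound 4 (0.78 log units; beyond the scatter) is expected to go toward a higher number, of moderate size and possibly beyond the scatter. Compound 4 is accordingly estimated at 400 nM, with a range of 100 nM to 1500 nM.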

Compound 4, half-maximal effective concentration: 208 nM
For compound 4 the middle estimate is 1.9-fold (0.28 log units) above the measured one; low and high end bracket the measured number.
By their numbers in this assay, from the lowest: compounds 3, 2 and 4 (each within the scatter of the next, the first and the last beyond it); then compound 1.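

In this assay the position on an aromatic carbon of a six-membered aromatic ring of carbon only, para to a large group, now has its first single-change reading: 2-(4-methoxyphenyl)ethenyl in place of 3-chloro-4-fluorophenyl gives a 3.2-fold higher number from compound 3 to compound 4 (0.50 log units; beyond the scatter) and the step is modest. The entering group brings a double bond outside aromatic rings and a hydrogen-bond acceptor and carries no chlorine or fluorine, so the position accepts a substantial exchange while the number stays in the same broad region as the other low values of the series. Compound 1 also carries a group with a double bond outside aromatic rings and gives 1470 nM whereas compound 4 gives 208 nM, so the presence of that double bond does not by itself go with a number as high as that of compound 1.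

Going by these compounds, the step changes the link and the ring substituents together, so the share of each stays open, and a directly attached 4-methoxyphenyl would be needed to separate them. Also open, on these data alone, is how this position behaves with an amine or a carboxylic acid on the terminal ring. Nothing at hand gives a reason for the size of this step.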